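A Methoxy Group Returns to the Chain

This account rests on a few compounds, and the source may have more. Where it says the series, first, only, none or still open, it means among the compounds named here.

Values in a functional assay on cells (Cancer cell lines, Homo sapiens) for inhibition, read by MTT assay, with a stated time of 48 h (a higher number here means a weaker inhibitor, a lower number a stronger inhibitor), for the measured compounds:
Compound 1 `COc1ccccc1/C=C/C(=O)NNC(=O)c1ccc2c(c1)OCCO2` gives 8060 nM
Compound 2 `O=C(/C=C/c1ccccc1F)NNC(=O)c1ccc2c(c1)OCCO2` gives 4510 nM
Compound 3 `O=C(/C=C/c1ccccc1Cl)NNC(=O)c1ccc2c(c1)OCCO2` gives 4880 nM

Compound 3 stands within the scatter of both others, as a 1.1-fold higher number from compound 2 to compound 3 (0.03 log units; within the scatter) and a 1.7-fold lower number from compound 1 to compound 3 (0.22 log units; within the scatter) show. Compound 4 `COc1cccc(/C=C/C(=O)NNC(=O)c2ccc3c(c2)OCCO3)c1` has not yet been measured. Among the compounds with values here, it carries 3-methoxyphenyl in place of 2-chlorophenyl on a double-bonded chain carbon bound to a double-bonded chain carbon and no measured compound bears this exact group. The closest evidence is compound 1, which also carries methoxy, and its step of a 1.8-fold lower number from compound 1 to compound 2 (0.25 log units; within the scatter) stays within the scatter too. The estimated step is a 1.2-fold higher number from compound 3 to compound 4 (0.09 log units; within the scatter) and none beyond the scatter is expected in this assay for this change. For compound 4 the estimated value is 6000 nM with 2800 nM to 13000 nM as the expected range.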

Compound 4, half-maximal inhibitory concentration: 170 nM
For compound 4 the middle estimate is 35-fold (1.55 log units) above the measured one, and the stated range ends above it.
By their numbers in this assay, from the lowest: compound 4; then compounds 2, 3 and 1 (each within the scatter of the next).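

In this assay, within the data shown here, the changes among the earlier compounds stayed within the scatter, yet 3-methoxyphenyl in place of 2-chlorophenyl gives a 29-fold lower number from compound 3 to compound 4 (1.46 log units; beyond the scatter) and in place of 2-fluorophenyl gives a 27-fold lower number from compound 2 to compound 4 (1.42 log units; beyond the scatter) at this place on the double-bonded chain carbon. Methoxy alone does not settle the outcome: 3-methoxyphenyl in place of 2-methoxyphenyl gives a 47-fold lower number from compound 1 to compound 4 (1.68 log units; beyond the scatter) and so the place of the group on the ring counts here. No measurement shown explains this difference. The compounds shown leave open whether a hydroxy group, an amine or an ethoxy group in place of the methoxy of compound 4 would keep so low a number.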